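Urea series on a shared core: toward compound 4

The source may report more compounds than this note shows. Statements on the series, on what has been measured and on what is new or still open speak of the compounds shown alone.

Compound 1 `COc1cc(NC(C)CCCNC(=O)Nc2cccc(F)c2)c2ncccc2c1`: 27000 nM
Compound 2 `COc1cc(NC(C)CCCNC(=O)Nc2ccc(Br)cc2)c2ncccc2c1`: 23000 nM
Compound 3 `COc1cc(NC(C)CCCNC(=O)Nc2ccc(F)cc2)c2ncccc2c1`: 25000 nM

All three were read in a functional assay on SW-620 cells (Homo sapiens) for inhibition, read by MTT assay, with a stated time of 72 h; on this read-out higher numbers stand for weaker inhibition and lower numbers for stronger inhibition. Compound 2 holds the lowest of the three numbers, yet every step to it stays within the scatter, so the three stand level. Compound 4 `COc1cc(NC(C)CCCNC(=O)NNC(=O)Nc2cccc(F)c2)c2ncccc2c1` is unmeasured; against compound 2 the change is ((3-fluorophenyl)carbamoyl)amino in place of 4-bromophenyl on an amide-type nitrogen. The measured steps of a 1.2-fold lower number from compound 1 to compound 2 (0.07 log units; within the scatter), a 1.1-fold lower number from compound 1 to compound 3 (0.03 log units; within the scatter) and a 1.1-fold higher number from compound 2 to compound 3 (0.04 log units; within the scatter) swap only the group on the amide-type nitrogen among close aryl variants, and none inserts further atoms between that nitrogen and the aryl group, so they speak to the present change only indirectly. No change beyond the scatter is expected; the step is estimated as a 1.3-fold higher number from compound 2 to compound 4 (0.12 log units; within the scatter), with a wide range. Compound 4 is expected near 30000 nM, between 10000 nM and 90000 nM.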

Compound 4, half-maximal inhibitory concentration: 9500 nM
Estimate against measurement, compound 4: 3.2-fold (0.50 log units) above; measured number below the stated range.
By their numbers in this assay, from the lowest: compound 4; then compounds 2, 3 and 1 (each within the scatter of the next).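

Putting ((3-fluorophenyl)carbamoyl)amino on the amide-type nitrogen gives a 2.4-fold lower number from compound 2 to compound 4 (0.38 log units; beyond the scatter) and a 2.6-fold lower number from compound 3 to compound 4 (0.42 log units; beyond the scatter) and a 2.8-fold lower number from compound 1 to compound 4 (0.45 log units; beyond the scatter) whereas the swaps among compound 1, compound 2 and compound 3 stayed within the scatter. This position therefore responds to the entering group, which keeps the six-membered aromatic ring and adds a carbonyl and two nitrogens, though each step remains modest. No evidence here bears on the origin of this shift.

From the compounds shown here alone, whether the same unit carrying 4-bromophenyl or 4-fluorophenyl gives a similar step remains open. So does the outcome with a cyclohexyl group or a longer chain on that nitrogen.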